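Three antiproliferative limits and a bromophenyl ethyl variant

This account rests on a few compounds, and the source may have more. Where it says the series, first, only, none or still open, it means among the compounds named here.

Compound 1, `COc1cccc(N(C)S(=O)(=O)C2CC3OC2C(c2ccc(NC(=O)CCCCCCC(=O)O)cc2)=C3c2ccc(O)cc2)c1`, in an ADME assay on Vero cells (Chlorocebus sabaeus) for antiproliferative activity, read by MTT assay, with a stated time of 72 h (on this read-out higher numbers stand for weaker inhibition and lower numbers for stronger inhibition), gives > 100000 nM, a limit of the assay rather than a number.
Compound 2, `CN(c1cccc2ccccc12)S(=O)(=O)C1CC2OC1C(c1ccc(NC(=O)CCCCCCC(=O)O)cc1)=C2c1ccc(O)cc1`, in this assay gives > 100000 nM, likewise a limit.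
Compound 3, `CCN(c1ccc(C)cc1)S(=O)(=O)C1CC2OC1C(c1ccc(NC(=O)CCCCCCC(=O)O)cc1)=C2c1ccc(O)cc1`, in this assay gives > 100000 nM, again a limit.

Compound 1 therefore stands at the limit, and it shares that position with the two others: the limit of > 100000 nM in this assay, at which 3 of the 3 values shown sit. The three structural steps among them, a step that the two limits leave unreadable from compound 1 to compound 2, a step that the two limits leave unreadable from compound 1 to compound 3 and a step that the two limits leave unreadable from compound 2 to compound 3, cannot be read in size, since both ends sit at the limit.

The unmeasured compound 4, `CCN(c1ccccc1Br)S(=O)(=O)C1CC2OC1C(c1ccc(NC(=O)CCCCCCC(=O)O)cc1)=C2c1ccc(O)cc1`, differs from compound 1 at the sulfonyl sulfur: (2-bromophenyl)(ethyl)amino in place of (3-methoxyphenyl)(methyl)amino on a sulfonyl sulfur. The measured steps that exchange the group on the sulfonamide nitrogen all start and end at the limit, so they give no readable size and no direction. For compound 4 in this assay the step that the limit leaves unreadable from compound 1 to compound 4 is expected to be nothing readable beyond the scatter. Compound 4 is thus expected to give 150000 nM, with a range from 50000 nM to 500000 nM, most likely reported again as a limit.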

Compound 4, half-maximal inhibitory concentration: > 100000 nM
Compound 4: no number, only a limit; the forecaster's own chance of this, stated with the estimate: 85%; the middle value is on the limit's open side.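

Compound 4 gives > 100000 nM, which is a limit and not a number. Its steps to compound 1, compound 2 and compound 3 therefore cannot be read in size: the limit of > 100000 nM in this assay, at which 4 of the 4 values shown sit.

The compounds shown leave open whether any group on the sulfonamide nitrogen changes the result in this assay at all.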